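The source may report more compounds than this note shows. Statements on the series, on what has been measured and on what is new or still open speak of the compounds shown alone.

Measured so far in a functional assay on MIA PaCa-2 cells (Homo sapiens) for inhibition, read by MTT assay, with a stated time of 72 h; a lower number here means a stronger inhibitor of growth, a higher number a weaker inhibitor of growth:

Compound 1 `O=S(=O)(NCCCNCc1ccc(C(F)(F)F)cc1)c1cc(C(F)(F)F)cc(C(F)(F)F)c1`: 2500 nM
Compound 2 `O=S(=O)(NCCCNCc1ccccc1)c1cc(C(F)(F)F)cc(C(F)(F)F)c1`: 11000 nM

Among the measured compounds shown here, compound 2 gives the highest of the two numbers so far; its nearest neighbour is compound 1, which gives the lower number. For the measured compounds named here, the one measured step within the pair, a 4.4-fold higher number from compound 1 to compound 2 (0.64 log units; beyond the scatter), is a modest rise that lies beyond the scatter, and it describes only the loss of trifluoromethyl on an aromatic carbon.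

Compound 3 `O=S(=O)(NCCCNCc1ccc(-c2ccccc2)cc1)c1cc(C(F)(F)F)cc(C(F)(F)F)c1` differs from compound 2 by phenyl in place of hydrogen on an aromatic carbon. This is the same place on the ring at which the step from compound 1 to compound 2 was seen, but phenyl is a different group from trifluoromethyl, so that step bears on it only loosely: it shows that an occupied position there went with a lower number than hydrogen, nothing more.

On that basis a modest step toward a lower number is expected for compound 3, a 2.8-fold lower number from compound 2 to compound 3 (0.44 log units; beyond the scatter), with broad uncertainty in both directions. The estimate for compound 3 in this assay is 4000 nM, expected to fall between 1200 nM and 13000 nM.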

Compound 3, concentration for 50% growth inhibition: 2400 nM
Beside the measured number, compound 3's estimate is 1.7-fold (0.22 log units) above it, and the stated range covers the measured number.
By their numbers in this assay, from the lowest: compounds 3 and 1 (each within the scatter of the next); then compound 2.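

In this assay, a second, quite different group at the aromatic carbon para to a large group goes with a lower number than hydrogen: a 4.6-fold lower number from compound 2 to compound 3 (0.66 log units; beyond the scatter), so the link between an occupied position and a lower number no longer rests on trifluoromethyl alone. Exchanging trifluoromethyl for phenyl, which brings 6 heavy atoms and a six-membered aromatic ring of carbon only, leaves the read-out unresolved: a 1.0-fold lower number from compound 1 to compound 3 (0.02 log units; within the scatter), so the two groups cannot be told apart at this position in this series. No measurement at hand accounts for the result.

Open, as far as these compounds go, is whether the lower number goes with any group at this carbon or only with these two; a carboxylic acid, an amine or a methoxy group at the same place would separate those readings. Also open, from the compounds shown here alone, is whether the step from hydrogen to phenyl holds on a core carrying a longer chain in place of the present one.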